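A methyl-to-methoxy swap on a biphenyl amide

The source may hold more compounds than are shown below. What is called first, only, known or untested is meant among the compounds shown, and "the series" means these compounds.

Two compounds share a core built from a phenyl-cyclopropane carboxamide attached to a biphenyl, with a basic amine side chain. Compound 1 `CN[C@@H](CC(C)C)CN(C(=O)[C@@H]1C[C@H]1c1ccccc1)c1ccc(-c2ccccc2)cc1` was tested in a functional assay for agonist activity at G protein-coupled receptor 88 (Homo sapiens), read by HTRF and cAMP accumulation (a lower number here means that less compound is needed, a higher number that more compound is needed for the effect), where compound 1 gives 2 nM. Compound 2 `CCc1ccc(-c2ccc(N(C[C@@H](N)[C@@H](C)CC)C(=O)[C@@H]3C[C@H]3c3ccccc3)cc2)cc1` carries a different amine side chain and an ethyl group on the outer ring; in this assay compound 2 gives 44 nM, the higher of the two numbers, and its gap to compound 1 lies beyond the usual scatter. Compound 1 and compound 2 differ in more than one place, so no single change can be read from their two values.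

Compound 3 `CC[C@H](C)[C@H](N)CN(C(=O)[C@@H]1C[C@H]1c1ccccc1)c1ccc(-c2ccc(COC)cc2)cc1` keeps the amine side chain of compound 2 and changes only the outer ring: methoxy in place of methyl on a saturated chain carbon bound to an aromatic carbon. Going by the values given here, no pair of measured compounds shows this change, so its size is unknown. A step from compound 2 to compound 3 within the scatter is expected, a 1.4-fold higher number from compound 2 to compound 3 (0.13 log units; within the scatter), with a small lean towards a higher number. For compound 3 the expected value in this assay is 60 nM, within a range from 15 nM to 250 nM.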

Compound 3, half-maximal effective concentration: 35 nM
Compound 3: middle estimate off by 1.7-fold (0.23 log units), on the high side; low and high end bracket the measured number.
By their numbers in this assay, from the lowest: compound 1; then compounds 3 and 2 (each within the scatter of the next).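

In this assay, replacing methyl with methoxy on a saturated chain carbon bound to an aromatic carbon gives a 1.3-fold lower number from compound 2 to compound 3 (0.10 log units; within the scatter) and turns 4-ethylphenyl into 4-(methoxymethyl)phenyl. The earlier compounds shown here gave no reading of this position on its own, and this pair shows that the two outer groups cannot be told apart in this read-out. The outer ring of compound 3 carries one more heavy atom, an oxygen, and a hydrogen-bond acceptor, and the number stays within the usual scatter of that of compound 2, while no independent evidence bears on what lies behind this result.

Going by these compounds, what stays open is the much lower number of compound 1, at 2 nM in this assay for a compound that differs from compound 2 and compound 3 in more than one place, so neither its amine side chain nor its outer ring can be credited on its own. The compounds shown also leave open whether this position would stay as quiet with an amine, a carboxylic acid or a longer ether chain at the end of the group.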